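A few compounds are considered here, and "the series" means these few. Any claim that something is new, unique, unknown or untested is made for them only; others in the source may bear on it.

Measured compounds:
Compound 1, `O[C@@H]1Cc2ccccc2[C@H]1NC1CCN(CCCc2c[nH]c3ccc(-n4cnnc4)cc23)CC1`: in an assay on CHO cells for displacement of a labelled ligand from 5-hydroxytryptamine receptor 1B (Homo sapiens) (a higher number here means a weaker inhibitor, a lower number a stronger inhibitor), compound 1 gives 210 nM.
Compound 2, `C[C@H](NCC1CCN(CCCc2c[nH]c3ccc(-n4cnnc4)cc23)CC1)c1ccccc1`: in this assay compound 2 gives 58 nM.
Compound 3, `CC(C)=CCN(C)C1CCN(CCCc2c[nH]c3ccc(-n4cnnc4)cc23)CC1`: in this assay compound 3 gives 41 nM.

Compound 3 shows the lowest of the three numbers, but one of the two steps leading to it is only a 1.4-fold lower number from compound 2 to compound 3 (0.15 log units; within the scatter), within the scatter, whereas the other is a 5.1-fold lower number from compound 1 to compound 3 (0.71 log units; beyond the scatter). Compound 4, `CN(Cc1ccco1)C1CCN(CCCc2c[nH]c3ccc(-n4cnnc4)cc23)CC1`, differs from compound 3 by furan-2-yl in place of 2-methylprop-1-en-1-yl on a saturated chain carbon bound to an amine nitrogen. For the measured compounds named here, no measured step exchanges this group for an aromatic ring; the nearest guide is a 1.4-fold lower number from compound 2 to compound 3 (0.15 log units; within the scatter), where swapping one amine substituent for another at this position changed little. A step of a 1.3-fold higher number from compound 3 to compound 4 (0.13 log units; within the scatter) is therefore expected, not beyond the scatter. Compound 4 is estimated at 55 nM, with a likely range from 20 nM to 150 nM.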

Compound 4, half-maximal inhibitory concentration: 89 nM
The estimate for compound 4 lay 1.6-fold (0.21 log units) below the measured number; the measured number falls inside the stated range.
By their numbers in this assay, from the lowest: compounds 3, 2 and 4 (each within the scatter of the next, the first and the last beyond it); then compound 1.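

Putting furan-2-yl in place of 2-methylprop-1-en-1-yl on this saturated chain carbon gives a change beyond the scatter in this assay (a 2.2-fold higher number from compound 3 to compound 4 (0.34 log units; beyond the scatter)), so this position does respond to what is attached there. The change of whole amine side group from compound 2 to compound 3 had not shown this. The other two comparisons give a step within the scatter (a 1.5-fold higher number from compound 2 to compound 4 (0.19 log units; within the scatter)) and one beyond it (a 2.4-fold lower number from compound 1 to compound 4 (0.37 log units; beyond the scatter)).

Going by these compounds, whether a phenyl or thiophen-2-yl ring on the same carbon would give a number like that of furan-2-yl stays open. Nothing shown here explains the step from 2-methylprop-1-en-1-yl to furan-2-yl.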